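The compounds below may be only part of what the source reports. "The series", "measured", "known", "first", "only" and "open" are said of these compounds alone.

Compound 2 `COc1ccc(-c2c(-c3ccc(OC)cc3)n(Cc3ccccc3)c3ncn(CCO)c(=N)c23)cc1` is measured in an ADME assay for permeability, using PAMPA, with a stated time of 30 min, at pH 7.4 (on this read-out higher numbers stand for higher permeability and lower numbers for lower permeability), and compound 2 gives > 1000 10^-6 cm/s, a limit of the assay rather than a number. Compound 1 `COc1ccc(-c2c(-c3ccc(OC)cc3)n(Cc3ccccc3)c3ncn(CC4CCOC4)c(=N)c23)cc1` likewise gives > 1000 10^-6 cm/s, again a limit of the assay. The step from compound 1 to compound 2, a step that the two limits leave unreadable from compound 1 to compound 2, which puts hydroxymethyl in place of oxolan-3-yl on a saturated chain carbon bound to an aromatic nitrogen, is therefore unreadable. Compound 3 `O[C@H]1CC[C@H](Nc2ncnc3c2c(-c2ccccc2)c(-c2ccccc2)n3Cc2ccccc2)CC1` in this assay has "nd" (no result reported), no result reported. The change now made leads to compound 4 `COc1ccc(-c2c(-c3ccc(OC)cc3)n(Cc3ccccc3)c3ncn(C4CCOCC4)c(=N)c23)cc1`, with oxan-4-yl in place of 2-hydroxyethyl on an aromatic nitrogen. Among the measured compounds shown here, since the limit of > 1000 10^-6 cm/s in this assay, at which 2 of the 3 values shown sit, holds both readable compounds, no measured step bears on this change, and no direction can be taken from the data. Compound 4 is nonetheless expected near the same limit, with a step that the limit leaves unreadable from compound 2 to compound 4, giving an estimate of 1500 10^-6 cm/s in a range from 700 10^-6 cm/s to 3000 10^-6 cm/s.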

Compound 4, apparent permeability: > 1000 10^-6 cm/s
Compound 4: no number, only a limit (the forecaster's own chance of this, stated with the estimate: 85%); the middle value is on the limit's open side.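

No step can be read among compound 1, compound 2 and compound 4 in this assay, since each gives only a limit of the assay: the limit of > 1000 10^-6 cm/s in this assay, at which 3 of the 4 values shown sit.
The compounds shown leave open how far these three actually differ, and whether oxan-4-yl in place of 2-hydroxyethyl changes the read-out at all.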